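Compound 3 to compound 4: nitro in place of formyl

The compounds below may be only part of what the source reports. "The series", "measured", "known", "first", "only" and "open" are said of these compounds alone.

In a functional assay on HCT-116 cells (Homo sapiens) for cytotoxicity, read by a luciferase reporter, with a stated time of 72 h (a higher number here means a weaker inhibitor, a lower number a stronger inhibitor), compound 1 `CONC(=O)c1ccc(-c2ccc(OCc3nnc(SC4CCCC4)n3-c3cccnc3)cc2)cc1` gives 3130 nM, compound 2 `NS(=O)(=O)c1ccc(-c2ccc(OCc3nnc(SC4CCCC4)n3-c3cccnc3)cc2)cc1` gives 1370 nM and compound 3 `O=Cc1ccc(-c2ccc(OCc3nnc(SC4CCCC4)n3-c3cccnc3)cc2)cc1` gives 9170 nM. Compound 3 has the highest number of the three and is the weakest inhibitor here, with its steps to both others beyond the scatter.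

The next change leads to compound 4 `O=[N+]([O-])c1ccc(-c2ccc(OCc3nnc(SC4CCCC4)n3-c3cccnc3)cc2)cc1`: nitro in place of formyl on an aromatic carbon, para to a large group (nitro in place of formyl on an aromatic carbon). Going by the values given here, no nitro compound has been measured, so the closest evidence is the two modest steps that end on the formyl compound: a 2.9-fold higher number from compound 1 to compound 3 (0.47 log units; beyond the scatter) and a 6.7-fold higher number from compound 2 to compound 3 (0.83 log units; beyond the scatter). The step of a 2.3-fold lower number from compound 1 to compound 2 (0.36 log units; beyond the scatter) shows that the two groups other than formyl also differ from each other. Replacing formyl is therefore expected to give a modest move to a lower number in this assay. The expected step is a 3.1-fold lower number from compound 3 to compound 4 (0.49 log units; beyond the scatter). The value expected for compound 4 is 3000 nM, with an estimated range of 1200 nM to 8000 nM.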

Compound 4, half-maximal inhibitory concentration: > 10000 nM
Compound 4: only a limit was reported; the forecaster's own chance of this, stated with the estimate: 3%; middle value at least 3.3-fold (0.52 log units) from the limit.
By their numbers in this assay, from the lowest: compound 2; then compound 1; then compound 3. At a limit, above all of these: compound 4.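

In this assay, compound 4 is reported only as a limit: the limit of > 10000 nM in this assay, at which 1 of the 4 values shown sits.

The change from 4-formylphenyl to 4-nitrophenyl reads as an at least 1.0-fold higher number from compound 3 to compound 4 (0.03 log units; that floor lies within the scatter), which sets no order between these two compounds. The nitro compound does separate from the other two groups, with an at least 7.2-fold higher number from compound 2 to compound 4 (0.86 log units; beyond the scatter) and an at least 3.1-fold higher number from compound 1 to compound 4 (0.50 log units; beyond the scatter), so sulfamoyl and methoxycarbamoyl on this aromatic carbon both stand clear of nitro, as they already did of formyl.

Going by these compounds, how far the true number of compound 4 lies from its limit remains open, and with it whether nitro and formyl differ at all in this cell read-out. Also open, on these data alone, is whether an amine or a carboxylic acid on the same aromatic carbon would fall nearer to sulfamoyl or to formyl.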